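The source may report more compounds than this note shows. Statements on the series, on what has been measured and on what is new or still open speak of the compounds shown alone.

Working notes on the series.

Compound 1 `CCC(C)C(NC(=O)n1nnc2ccccc21)C(=O)NCc1ccccc1` gives > 100000 nM in a functional assay on HEp-2 cells (Homo sapiens) for inhibition (a lower number here means a stronger inhibitor, a higher number a weaker inhibitor), a limit of the measurement and not a number. Compound 3 `CCC(C)C(NC(=O)n1nnc2ccccc21)C(=O)NC(c1ccccc1)c1ccccc1` gives 55300 nM in this assay. Among the measured compounds shown here, the one measured step is an at least 1.8-fold lower number from compound 1 to compound 3 (0.25 log units; that floor lies within the scatter), and its floor lies within the scatter. Compound 2 `CC(C)C(NC(=O)NO)C(=O)NC1CCCCC1` gives > 100000 nM in this assay, again a limit rather than a number. So on the numbers shown compound 2 stands at the limit of > 100000 nM in this assay, at which 2 of the 3 values shown sit, with nothing finer known about it.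

Compound 4 `CCC(C)C(NC(=O)NO)C(=O)NC1CCCCC1` differs from compound 2 in one place: methyl in place of hydrogen on a saturated chain carbon, three bonds along the chain from an amide-type nitrogen and a carbonyl carbon. For the measured compounds named here, no measured step touches this position; the one measured step alters a different part of the shared core and its floor lies within the scatter. There is thus no ground to expect a step beyond the scatter in this assay, in either direction, and no ground to expect compound 4 to leave the limit at which compound 2 sits. Compound 4 is expected to give 150000 nM, within 50000 nM to 500000 nM, most probably reported only as a limit. The expected step is a step that the limit leaves unreadable from compound 2 to compound 4, that is, none beyond the scatter.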

Compound 4, half-maximal inhibitory concentration: > 100000 nM
Compound 4 ended at the assay's limit; the forecaster's own chance of this, stated with the estimate: 85%; the middle value does not contradict the limit.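

Compound 2 and compound 4 each give a limit and not a number in this assay, so no step can be read between them, and compound 4 stands with compound 2 at: the limit of > 100000 nM in this assay, at which 3 of the 4 values shown sit.

The compounds shown leave open whether methyl in place of hydrogen at this place changes inhibition at all, since neither compound has a value inside the readable range.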